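Swapping the Chain on the Ring Nitrogen of Compound 1

This account rests on a few compounds, and the source may have more. Where it says the series, first, only, none or still open, it means among the compounds named here.

Three compounds have been measured:
compound 1, `CN1CCN(c2ccc(Nc3ncc4nc(Nc5ccc(F)cc5)n(CCNS(=O)(=O)C5CC5)c4n3)cc2)CC1`, 50 nM
compound 2, `CN1CCN(c2ccc(Nc3ncc4nc(Nc5ccc(F)cc5)n([C@H]5CCCN(S(=O)(=O)C6CC6)C5)c4n3)cc2)CC1`, 8.6 nM
compound 3, `CC(=O)Nc1cccc(-n2c(Nc3ccc(F)cc3)nc3cnc(Nc4ccc(N5CCN(C)CC5)cc4)nc32)c1`, 10 nM

All three were tested in a functional assay on HCC827 cells (Homo sapiens) for antiproliferative activity, read by MTT assay, with a stated time of 72 h; a higher number here means a weaker inhibitor, a lower number a stronger inhibitor. Among these three numbers compound 1 gives the highest; compound 3 is nearest to it and compound 2 furthest, and both gaps lie beyond the scatter. Compound 4, `CN1CCN(c2ccc(Nc3ncc4nc(Nc5ccc(F)cc5)n(-c5cccc(NC(=O)CO)c5)c4n3)cc2)CC1`, has not yet been measured. It differs from compound 1 in one place: 3-(((hydroxymethyl)carbonyl)amino)phenyl in place of 2-((cyclopropylsulfonyl)amino)ethyl on an aromatic nitrogen. Among the measured compounds shown here, two measured steps bear on this change, since each replaces the same group on the same aromatic nitrogen. The step of a 5.8-fold lower number from compound 1 to compound 2 (0.76 log units; beyond the scatter) and the step of a 5.0-fold lower number from compound 1 to compound 3 (0.70 log units; beyond the scatter) each gave a modestly lower number. Compound 3 is the closer model, as its 3-acetamidophenyl group is the nearest measured relative of the entering group, and the step of a 1.2-fold higher number from compound 2 to compound 3 (0.07 log units; within the scatter) shows that the two measured replacements landed close together. A lower number is therefore expected for compound 4 in this assay, in line with what compound 3 showed. For compound 4 the expected step in this assay is a 4.2-fold lower number from compound 1 to compound 4 (0.62 log units; beyond the scatter). Compound 4 is estimated at 12 nM, with a range from 5 nM to 30 nM.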

Compound 4, half-maximal inhibitory concentration: 7.5 nM
Compound 4: middle estimate off by 1.6-fold (0.20 log units), on the high side, and the stated range covers the measured number.
By their numbers in this assay, from the lowest: compounds 4, 2 and 3 (each within the scatter of the next); then compound 1.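

In this assay, the 3-(((hydroxymethyl)carbonyl)amino)phenyl group gives a 6.7-fold lower number from compound 1 to compound 4 (0.82 log units; beyond the scatter) when it takes the place of the 2-((cyclopropylsulfonyl)amino)ethyl chain, so a third replacement on this aromatic nitrogen also lands beyond the scatter of compound 1. The new compound also offers the first change made within one of these entering groups: hydroxy in place of hydrogen on the saturated chain carbon bound to the carbonyl carbon gives a 1.3-fold lower number from compound 3 to compound 4 (0.12 log units; within the scatter) and so leaves the number within the scatter. The comparison with the 1-(cyclopropylsulfonyl)piperidin-3-yl group gives a 1.1-fold lower number from compound 2 to compound 4 (0.06 log units; within the scatter) and is also within the scatter, so compounds 2, 3 and 4 stand level in this read-out although their entering groups differ in ring type.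

Nothing presented here accounts for these numbers or for why the three replacements fall so close together. Still open, as far as these compounds go, is whether an amine or a carboxylic acid in place of the hydroxy, or a longer chain carrying that hydroxy, would move the number beyond the scatter of compound 4 in this assay and so show a limit to what this position accepts.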